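Three Compounds at the Limit, a Fourth Awaiting Measurement

The compounds below may be only part of what the source reports. "The series", "measured", "known", "first", "only" and "open" are said of these compounds alone.

The set examined in an ADME assay on HEK293 cells (Homo sapiens) for cytotoxicity, with a stated time of 72 h (a lower number here means that less compound is needed, a higher number that more compound is needed for the effect), holds three measured compounds and one still to be measured. Compound 1 `COc1ccc(NC(=O)Nc2cc(C)nc3ccccc23)cc1` reaches only the limit of the assay, > 25000 nM. Compound 2 `Cc1cc(NC(=O)Nc2ccc(O)cc2)c2ccccc2n1` likewise stands at the limit, > 25000 nM. Compound 3 `Cc1cc(NC(=O)Nc2ccc(C(N)=O)cc2)c2ccccc2n1`, the starting point of the step followed here, also sits at the limit, > 25000 nM. Among the three there is no readable step: the change from the first to the second is a step that the two limits leave unreadable from compound 1 to compound 2, the change from the first to the third is a step that the two limits leave unreadable from compound 1 to compound 3, and the change from the second to the third is a step that the two limits leave unreadable from compound 2 to compound 3, since all three values rest at the limit of > 25000 nM in this assay, at which 3 of the 3 values shown sit.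

Compound 4 `Cc1cc(NC(=O)Nc2ccc(SC(F)(F)F)cc2)c2ccccc2n1` differs from compound 3 by (trifluoromethyl)sulfanyl in place of carbamoyl on an aromatic carbon. Among the measured compounds shown here, none of the measured steps bears on this change with a number, so no size can be drawn from them, and the only guide is that every measured compound rests at the limit of > 25000 nM in this assay, at which 3 of the 3 values shown sit.

On that basis compound 4 is expected to stay close to the limit in this assay, estimated at 30000 nM, with a range from 8000 nM to 100000 nM. The step this expectation implies is a step that the limit leaves unreadable from compound 3 to compound 4.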

Compound 4, half-maximal effective concentration: 13000 nM
Compound 4: middle estimate off by 2.3-fold (0.36 log units), on the high side, and the stated range covers the measured number.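

Compound 4 is the only one of the four compounds to give a number rather than a limit in this assay, so (trifluoromethyl)sulfanyl, on an aromatic carbon para to a large group, is the one group shown at this position that brings a value into the readable range. Putting it in place of carbamoyl gives an at least 1.9-fold lower number from compound 3 to compound 4 (0.28 log units; that floor lies within the scatter), in place of hydroxy it gives an at least 1.9-fold lower number from compound 2 to compound 4 (0.28 log units; that floor lies within the scatter), and in place of methoxy it gives an at least 1.9-fold lower number from compound 1 to compound 4 (0.28 log units; that floor lies within the scatter). These steps are floors and fix no true size, because each of the other three compounds gives only a limit: the limit of > 25000 nM in this assay, at which 3 of the 4 values shown sit.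

The compounds shown leave open whether the number at this position depends on the sulfur, on the fluorine atoms or on the group as a whole, and whether a trifluoromethyl group or a chlorine atom on the same carbon would also give a number in this assay. Also open, as far as these compounds go, is whether an amine or a carboxylic acid at this position would give a number or a limit, and whether a change to the shared core would move the value of compound 4.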